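This account rests on a few compounds, and the source may have more. Where it says the series, first, only, none or still open, it means among the compounds named here.

Two compounds of the series have so far been run in a functional assay on SW-620 cells (Homo sapiens) for antiproliferative activity, read by MTT assay, with a stated time of 24 h; a lower number here means a stronger inhibitor, a higher number a weaker inhibitor. Compound 1 `COc1ccc(C(=O)/C=C/c2ccc(-c3ccccc3)cc2)c2c1C=CC(C)(C)O2` reaches only the limit of this assay, reported as > 10000 nM. Going by the values given here, compound 2 `COc1ccc(C(=O)/C=C/c2ccc(N3CCCC3)cc2)c2c1C=CC(C)(C)O2` in this assay gives 7150 nM, the single numerical value so far. Among the compounds with values here, the one measured step, an at least 1.3-fold lower number from compound 1 to compound 2 (0.14 log units; that floor lies within the scatter), is bounded by the limit of > 10000 nM in this assay, at which 1 of the 2 values shown sits, and cannot be set larger than its floor. Compound 3 `COc1ccc(C(=O)/C=C/c2ccc([N+](=O)[O-])cc2)c2c1C=CC(C)(C)O2` differs from compound 2 by nitro in place of pyrrolidin-1-yl on an aromatic carbon. Within the data shown here, no measured step exchanges a nitro for pyrrolidin-1-yl, so the step of a 1.1-fold higher number from compound 2 to compound 3 (0.05 log units; within the scatter) is expected to stay small and not clearly beyond the scatter. Compound 3 is estimated at 8000 nM, within 2500 nM to 30000 nM.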

Compound 3, half-maximal inhibitory concentration: 3520 nM
Compound 3: the middle estimate sits 2.3-fold (0.36 log units) above what was measured, within the range that was stated.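

Going by these compounds alone, with a 2.0-fold lower number from compound 2 to compound 3 (0.31 log units; beyond the scatter) the aromatic carbon para to a large group shows for the first time in this assay a change beyond the scatter. Of the three groups at this place, nitro gives the lowest number, so the group there does move the read-out, if modestly. Compound 1 stands at a limit of the assay, so an at least 2.8-fold lower number from compound 1 to compound 3 (0.45 log units; beyond the scatter) is a floor only: the limit of > 10000 nM in this assay, at which 1 of the 3 values shown sits.

Going by these compounds, whether a primary amine or a carboxylic acid at this place would go lower remains open. Nothing shown yet tells how far the number can fall through this position alone.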